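Lengthening the Alkyl Chain on a Cyclic Phosphate Nucleoside

This account rests on a few compounds, and the source may have more. Where it says the series, first, only, none or still open, it means among the compounds named here.

The measured compounds:
compound 1, `CCCc1cn([C@H]2C[C@@H]3OP(=O)(O)OC[C@H]3O2)c(=O)[nH]c1=O` — > 500 ug/mL
compound 2, `CCCCCc1cn([C@H]2C[C@H](O)[C@@H](CO)O2)c(=O)[nH]c1=O` — 334 ug/mL
compound 3, `CCCc1cn([C@H]2C[C@H](O)[C@@H](CO)O2)c(=O)[nH]c1=O` — > 500 ug/mL

In a functional assay on Raji cells (Homo sapiens) (a lower number here means a stronger inhibitor, a higher number a weaker inhibitor), compound 1 gives > 500 ug/mL, which is a limit of the assay and not a number. Compound 3 likewise gives only a limit, > 500 ug/mL. Among the compounds with values here, compound 2 is the one compound with a number, 334 ug/mL. Two of the three values therefore sit at the same point, (the limit of > 500 ug/mL in this assay, at which 2 of the 3 values shown sit).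

Compound 4, `CCCCCc1cn([C@H]2C[C@@H]3OP(=O)(O)OC[C@H]3O2)c(=O)[nH]c1=O`, differs from compound 1 in one place: ethyl in place of hydrogen on a saturated chain carbon, three bonds along the chain from an aromatic carbon. Within the data shown here, the only measured step that bears on this change runs in the opposite direction on the open-chain core: an at least 1.4-fold higher number from compound 2 to compound 3 (0.17 log units; that floor lies within the scatter). Read in reverse, it suggests that the longer chain may bring the number down a little, but that floor lies within the scatter, and compound 1 starts from a limit, so there is little to build on.

Compound 4 is therefore expected to give a number close to or at the limit, an at least 1.2-fold lower number from compound 1 to compound 4 (0.09 log units; that floor lies within the scatter). The estimate for compound 4 is 400 ug/mL, with a range from 250 ug/mL to 550 ug/mL.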

Compound 4, concentration for 50% inhibition: > 500 ug/mL
Compound 4 gave a limit, no number; the forecaster's own chance of this, stated with the estimate: 45%; middle value at least 1.2-fold (0.09 log units) away from the limit.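

In this assay compound 4 gives > 500 ug/mL, a limit and not a number. Compound 1 also gives only a limit, so no step can be read between compound 1 and compound 4: the limit of > 500 ug/mL in this assay, at which 3 of the 4 values shown sit.

The compounds shown leave open whether ethyl in place of hydrogen changes the number on the core of compound 1 at all.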